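A Methyl on the Ring Nitrogen of a Stilbene Series

A few compounds are considered here, and "the series" means these few. Any claim that something is new, unique, unknown or untested is made for them only; others in the source may bear on it.

Three compounds built on a shared core, a double bond joining two ring systems, have been tested in a functional assay on HT-29 cells (Homo sapiens) for inhibition; on this read-out higher numbers stand for weaker inhibition and lower numbers for stronger inhibition. Compound 1 `C(=C\c1ccc2[nH]ccc2c1)\c1ccc2ccccc2c1` gives only a limit of the assay, > 5000 nM. Compound 2 `Cn1ccc2cc(/C=C\c3ccc4ccccc4c3)ccc21` likewise gives a limit, > 5000 nM. The two differ in one place: methyl in place of hydrogen on an aromatic nitrogen. The measured step that the two limits leave unreadable from compound 1 to compound 2 cannot be sized because of the limit of > 5000 nM in this assay, at which 2 of the 3 values shown sit. Compound 3 `COc1cc(/C=C/c2ccc3[nH]ccc3c2)cc(OC)c1OC` differs from compound 1 by more than one place; the difference between the two cores is not broken down here. In this assay, among the compounds with values here, compound 3 gives 280 nM, the one number among the three results. Compound 4 `COc1cc(/C=C/c2ccc3c(ccn3C)c2)cc(OC)c1OC` has not yet been measured; it differs from compound 3 by methyl in place of hydrogen on an aromatic nitrogen, the same change as that between compound 1 and compound 2, made at the same place. Beside the unreadable measured step, the step expected from compound 3 to compound 4 is a 1.4-fold higher number from compound 3 to compound 4 (0.15 log units; within the scatter). That expectation rests on compound 3 alone, anchored by 280 nM. Compound 4 is therefore estimated at 400 nM, within a range from 80 nM to 3000 nM.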

Compound 4, half-maximal inhibitory concentration: 280 nM
The estimate for compound 4 lay 1.4-fold (0.15 log units) above the measured number; the range from low to high includes it.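

In this assay, methyl in place of hydrogen on an aromatic nitrogen gives no change at the digits printed from compound 3 to compound 4 (within the scatter). On the core of compound 3, then, the hydrogen on that nitrogen can give way to methyl and the two compounds still read alike, which is a finding about this one core and this one read-out. It does not show that the change behaves the same way on the core of compound 1, and the step there cannot be read, so the two cores cannot be compared, because compound 1 and compound 2 each give a limit of the assay rather than a number: the limit of > 5000 nM in this assay, at which 2 of the 4 values shown sit.

The compounds shown leave open what a group other than methyl would do on that nitrogen, such as an ethyl group, a longer chain, or a chain ending in an amine or a carboxylic acid. They also leave open whether the match between compound 3 and compound 4 would hold on any further core.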